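Swapping Fluoro for Methyl on the Outer Ring

The source may report more compounds than this note shows. Statements on the series, on what has been measured and on what is new or still open speak of the compounds shown alone.

Compound 1 `COc1cc(COCc2cn(Cc3cc(C)cnc3Cl)nn2)cc(OC)c1OC` gives 264000 nM
Compound 2 `COc1cc(COCc2cn(Cc3cc(-c4ccc(F)cc4)cnc3Cl)nn2)cc(OC)c1OC` gives 49600 nM
Compound 3 `COc1cc(COCc2cn(Cc3cc(-c4ccc(C)cc4)cnc3Cl)nn2)cc(OC)c1OC` is not yet measured

In a functional assay on HeLa cells (Homo sapiens) for cytotoxicity, read by MTT assay, with a stated time of 48 h (on this read-out higher numbers stand for weaker inhibition and lower numbers for stronger inhibition), compound 2 has the lower of the two numbers (49600 nM) and so inhibits more strongly than compound 1. Compound 3 carries methyl in place of fluoro on an aromatic carbon, para to a large group (methyl in place of fluoro on an aromatic carbon). Among the compounds with values here, only one measured step bears on this, and only indirectly (a 5.3-fold lower number from compound 1 to compound 2 (0.73 log units; beyond the scatter)). That step is modest, and it brought in the whole 4-fluorophenyl in place of methyl. Within the data shown here, no measured pair exchanges fluoro for methyl, so the data do not show the size of this change directly. Only a small move is therefore expected, within the scatter and with no firm direction (a 1.1-fold lower number from compound 2 to compound 3 (0.04 log units; within the scatter)). Compound 3 is estimated at 45000 nM (expected range 20000 nM to 100000 nM).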

Compound 3, half-maximal inhibitory concentration: 28600 nM
Beside the measured number, compound 3's estimate is 1.6-fold (0.20 log units) above it; measured number inside the range.
By their numbers in this assay, from the lowest: compounds 3 and 2 (each within the scatter of the next); then compound 1.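

In this assay the exchange of fluoro for methyl on the outer ring gives a 1.7-fold lower number from compound 2 to compound 3 (0.24 log units; within the scatter) and this lies within the scatter, so these two groups cannot be told apart at this position. The larger step holds with methyl on the outer ring as well: the change gives a 9.2-fold lower number from compound 1 to compound 3 (0.97 log units; beyond the scatter) and this lies beyond the scatter, so the earlier step does not depend on fluoro alone. Nothing measured here explains the behaviour of either group.

On these data alone, what remains open is whether a different group at this position, such as an amine or a carboxylic acid, would shift the number beyond the scatter. Also open, as far as these compounds go, is whether the outer ring would give a similar result with its group placed elsewhere on that ring.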